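A few compounds are considered here, and "the series" means these few. Any claim that something is new, unique, unknown or untested is made for them only; others in the source may bear on it.

Of the compounds shown here, three on a shared core have been measured in a functional assay on HCT-116 cells (Homo sapiens) for antiproliferative activity, read by MTT assay, with a stated time of 48 h; on this read-out lower numbers stand for stronger inhibition and higher numbers for weaker inhibition. Compound 1 `N#CC1=C(N)Oc2c(c3nc4ccccc4nc3c3ccccc23)C12C(=O)N(Cc1cnnn1-c1cccc(Cl)c1)c1ccccc12` gives only a limit of the assay, > 50000 nM. Compound 2 `N#CC1=C(N)Oc2c(c3nc4ccccc4nc3c3ccccc23)C12C(=O)N(Cc1cnnn1-c1ccc(Br)cc1)c1ccccc12` likewise gives only a limit, > 50000 nM. The step that the two limits leave unreadable from compound 1 to compound 2 therefore cannot be read. For the measured compounds named here, compound 3 `N#CC1=C(N)Oc2c(N)cc3nc4ccccc4nc3c2C12C(=O)N(Cc1cnnn1-c1ccccc1Br)c1ccccc12` gives 12400 nM, the only number among the values shown; the other two sit at the limit of > 50000 nM in this assay, at which 2 of the 3 values shown sit. Compound 4 `N#CC1=C(N)Oc2c(N)cc3nc4ccccc4nc3c2C12C(=O)N(Cc1cnnn1-c1ccc(F)c(Cl)c1)c1ccccc12` differs from compound 3 by 3-chloro-4-fluorophenyl in place of 2-bromophenyl on an aromatic nitrogen. Going by the values given here, no measured step touches this change, and the single step between measured compounds is unreadable, so no size or direction beyond the scatter can be drawn for this assay. Compound 4 is expected at 12000 nM, with a range from 3000 nM to 50000 nM. The step of a 1.0-fold lower number from compound 3 to compound 4 (0.01 log units; within the scatter) that this estimate means is expected to lie within the scatter.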

Compound 4, half-maximal inhibitory concentration: > 50000 nM
Compound 4 was reported as a limit; the forecaster's own chance of this, stated with the estimate: 30%; middle value at least 4.1-fold (0.61 log units) away from the limit.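

For the compounds shown here, the step of an at least 4.0-fold higher number from compound 3 to compound 4 (0.60 log units; beyond the scatter) is the first readable one in this assay, and it shows that the group on this aromatic nitrogen matters on the shared core of compound 3. 3-Chloro-4-fluorophenyl in place of 2-bromophenyl moves the read-out to a limit, so the full size of the step cannot be read. Compound 3 thus stays the only compound with a number: the limit of > 50000 nM in this assay, at which 3 of the 4 values shown sit.

From the compounds shown here alone, what stays open is how much of the step belongs to losing the bromine and how much to gaining the chlorine and fluorine. Nor do the compounds shown tell how an unsubstituted phenyl or a benzyl on this nitrogen would read.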